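The compounds below may be only part of what the source reports. "The series", "measured", "known", "first", "only" and "open" are said of these compounds alone.

Measured so far in a physicochemical assay for solubility, in phosphate buffer, measured as kinetic solubility; a lower number here means a less soluble compound, a higher number a more soluble compound:

compound 1 `CC(C)C(Nc1nccs1)c1ccc(-c2ccc3cccc(F)c3c2)[nH]c1=O` — 16100 nM
compound 2 `CCn1ncc2c(F)cc(-c3ccc(C(CC)(CC)c4nnc(C)[nH]4)c(=O)[nH]3)cc21` — 26900 nM
compound 3 `CC(C)[C@H](C[C@H]1CCNC1=O)c1ccc(-c2ccc3cccc(F)c3c2)[nH]c1=O` — 26800 nM

Compound 1 has the lowest of the three numbers in this assay, but its gaps to compound 3 and to compound 2 both fall within the scatter of repeated measurements, so the three compounds are not separated by these data. Within the data shown here, no pair among them differs in only one place, so no single step in this assay is known for the series.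

Compound 4 `CC(C)C(c1noc(=O)[nH]1)c1ccc(-c2ccc3cccc(F)c3c2)[nH]c1=O` is the next compound for this assay. It differs from compound 1 as follows: a group of 6 heavy atoms (2 carbon, 2 nitrogen, 2 oxygen; one five-membered aromatic ring with 3 hetero atoms) in place of a group of 6 heavy atoms (3 carbon, 2 nitrogen, 1 sulfur; one five-membered aromatic ring with 2 hetero atoms), on a saturated chain carbon bound to an aromatic carbon and a saturated chain carbon. The shared core and the rest of the molecule are unchanged.

Among the measured compounds shown here, no measured step in this assay gives a reference for this kind of exchange. The expectation is therefore a small change, most likely within the scatter, with a lean to a somewhat higher number. For compound 4 the estimate in this assay is 20000 nM, with a range of 8000 nM to 50000 nM. This estimate means a step of a 1.2-fold higher number from compound 1 to compound 4 (0.09 log units; within the scatter).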

Compound 4, solubility: 32500 nM
Compound 4: the middle estimate sits 1.6-fold (0.21 log units) below what was measured, within the range that was stated.
By their numbers in this assay, from the lowest: compounds 1, 3, 2 and 4 (each within the scatter of the next, the first and the last beyond it).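

In this assay the saturated chain carbon bound to an aromatic carbon and a saturated chain carbon now has its first measured exchange: replacing (1,3-thiazol-2-yl)amino with the five-membered aromatic ring with 3 hetero atoms gives a 2.0-fold higher number from compound 1 to compound 4 (0.31 log units; beyond the scatter) and separates two compounds by a change in one place. The step is modest, and the counts of heavy atoms, hydrogen-bond donors and hydrogen-bond acceptors stay the same across the exchange. No measurement available here accounts for the step.

From the compounds shown here alone, it remains open how a carboxylic acid or a primary amine on this same carbon would compare with compound 1 and compound 4. Going by these compounds, this reading rests on a single pair, so it is also open whether the same exchange gives a similar step on another core.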